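A Longer Bromophenyl Tether on the Stilbene Ether

The source may report more compounds than this note shows. Statements on the series, on what has been measured and on what is new or still open speak of the compounds shown alone.

Compound 2 `COc1ccc(/C=C\c2cc(OC)c(OC)c(OC)c2)cc1OCc1ccc(Br)cc1` carries a 4-bromophenyl group on a saturated chain carbon bound to an oxygen on an aromatic ring. In a functional assay on MCF7 cells (Homo sapiens) for inhibition, read by MTT assay, with a stated time of 3 days (on this read-out higher numbers stand for weaker inhibition and lower numbers for stronger inhibition), compound 2 gives 29000 nM, the highest of the two numbers measured here, while compound 1 `C/C=C/COc1cc(/C=C\c2cc(OC)c(OC)c(OC)c2)ccc1OC` gives 5400 nM. Among the compounds with values here, the only measured step, a 5.4-fold higher number from compound 1 to compound 2 (0.73 log units; beyond the scatter), arose from a 4-bromophenyl in place of prop-1-en-1-yl at that position. Compound 3 `COc1ccc(/C=C\c2cc(OC)c(OC)c(OC)c2)cc1OCCC/C=C/c1ccc(Br)cc1` differs from compound 2 by a group of 11 heavy atoms (10 carbon, 1 bromine; one six-membered aromatic ring of carbon only) in place of a group of 7 heavy atoms (6 carbon, 1 bromine; one six-membered aromatic ring of carbon only), on a saturated chain carbon bound to an oxygen on an aromatic ring. Within the data shown here, that single step shows the number rising beyond the scatter when a short unsaturated chain gave way to a bromophenyl, yet compound 3 holds both a chain with a double bond and a bromophenyl, and no measured pair tells how lengthening the tether acts. A step of a 1.5-fold lower number from compound 2 to compound 3 (0.16 log units; within the scatter) is therefore expected, staying within the scatter. Compound 3 is estimated at 20000 nM in this assay, with a range from 7000 nM to 60000 nM.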

Compound 3, half-maximal inhibitory concentration: 37000 nM
Beside the measured number, compound 3's estimate is 1.9-fold (0.27 log units) below it; measured number inside the range.
By their numbers in this assay, from the lowest: compound 1; then compounds 2 and 3 (each within the scatter of the next).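

Replacing 4-bromophenyl with the larger group of 11 heavy atoms, which adds a double bond outside aromatic rings, gives a 1.3-fold higher number from compound 2 to compound 3 (0.11 log units; within the scatter), so at this saturated chain carbon bound to an oxygen on an aromatic ring, the two bromine-bearing groups cannot be told apart. The other new comparison gives a 6.9-fold higher number from compound 1 to compound 3 (0.84 log units; beyond the scatter), showing that a double bond in the chain does not by itself restore the lower number of compound 1 when the larger group also carries the bromophenyl ring. No measurement shown here accounts for these numbers.

The compounds shown leave open whether the bromine matters, which a plain phenyl group on the same chain would test. They also leave open how a chain ending in an amine or a carboxylic acid would read in this assay.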